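Swapping the Carboxy Ring of Compound 2

This account rests on a few compounds, and the source may have more. Where it says the series, first, only, none or still open, it means among the compounds named here.

In a functional assay on HeLa cells (Homo sapiens) for antiproliferative activity, read by CCK-8 assay, with a stated time of 48 h (a lower number here means a stronger inhibitor, a higher number a weaker inhibitor), compound 1 `COc1ccc(/C=C\c2cc(OC)c(OC)c(OC)c2)cc1OCc1ccc(C=O)cc1` gives 4800 nM. As far as these compounds go, compound 2 `COc1ccc(/C=C\c2cc(OC)c(OC)c(OC)c2)cc1OCc1ccc(CN2CCCC[C@H]2C(=O)O)cc1` gives > 10000 nM, which is a limit of the assay and not a number, so its exact standing is unknown. Compound 3 `COc1ccc(/C=C\c2cc(OC)c(OC)c(OC)c2)cc1OCc1ccc(CN2CC[C@H](C(=O)O)C2)cc1` changes one group of compound 2: 3-carboxypyrrolidin-1-yl takes the place of 2-carboxypiperidin-1-yl on a saturated chain carbon bound to an aromatic carbon, (3-carboxypyrrolidin-1-yl in place of 2-carboxypiperidin-1-yl on a saturated chain carbon bound to an aromatic carbon). Among the compounds with values here, no measured step tests this swap directly. Within the data shown here, the only step that bears on it is an at least 2.0-fold higher number from compound 1 to compound 2 (0.31 log units; beyond the scatter), which put (2-carboxypiperidin-1-yl)methyl in place of formyl and lies beyond the scatter. Given an at least 2.0-fold higher number from compound 1 to compound 2 (0.31 log units; beyond the scatter), and since the incoming group also carries a carboxy group, the expected step in this assay is a step that the limit leaves unreadable from compound 2 to compound 3, probably none beyond the scatter. Compound 3 is estimated at 12000 nM, with an expected range of 6000 nM to 30000 nM.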

Compound 3, half-maximal inhibitory concentration: > 10000 nM
Compound 3: a limit, no number; the forecaster's own chance of this, stated with the estimate: 70%; the middle value is on the limit's open side.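

In this assay, (3-carboxypyrrolidin-1-yl)methyl in place of formyl gives an at least 2.0-fold higher number from compound 1 to compound 3 (0.31 log units; beyond the scatter), so the loss seen with compound 2 is not confined to the 2-carboxypiperidin-1-yl ring. The step between compound 2 and compound 3 cannot be read, as each value is a limit and not a number, and neither ring can be ranked against the other. All that this pair can show is capped by one ceiling: the limit of > 10000 nM in this assay, at which 2 of the 3 values shown sit.

Both rings carry a carboxy group and a ring nitrogen, and the compounds shown leave open which of these goes with the loss. A plain piperidin-1-yl ring or a methyl ester of the carboxylic acid, in the same place, would pull the two apart.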